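Adding Two More Chain Carbons

This account rests on a few compounds, and the source may have more. Where it says the series, first, only, none or still open, it means among the compounds named here.

In a functional assay on MCF7 cells (Homo sapiens) for cytotoxicity (a lower number here means a stronger inhibitor, a higher number a weaker inhibitor), compound 1 `C#C[C@H](O)/C=C/CCCCC/C=C\CCCC/C=C\CCCCCCCCC/C=C/[C@@H](O)C#C` gives 160 nM. Going by the values given here, compound 2 `C#C[C@H](O)/C=C/CCCCCCC/C=C\CCCC/C=C\CCCCCCCCC/C=C/[C@@H](O)C#C` gives 160 nM, which leaves it level with compound 1 on the numbers so far.

Compound 3 `C#C[C@H](O)/C=C/CCCCCCCCC/C=C\CCCC/C=C\CCCCCCCCC/C=C/[C@@H](O)C#C` differs from compound 2 by a group of 8 heavy atoms (7 carbon, 1 oxygen; no ring) in place of a group of 6 heavy atoms (5 carbon, 1 oxygen; no ring), on a saturated chain carbon, seven bonds along the chain from a double-bonded chain carbon. This is a swap of the same size as the one already measured, but it sits on a saturated chain carbon seven bonds along the chain from a double-bonded chain carbon, rather than five.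

Among the compounds with values here, the only measured step that bears on it is no change at the digits printed from compound 1 to compound 2 (within the scatter). On that single step, no shift beyond the scatter is expected in this assay, although one step is slender evidence. The estimated change is no change at the digits printed from compound 2 to compound 3 (within the scatter). Compound 3 is expected at about 160 nM, within an estimated range of 70 nM to 380 nM.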

Compound 3, half-maximal inhibitory concentration: 160 nM
Beside the measured number, compound 3's estimate shows no gap at the digits printed, within the range that was stated.
By their numbers in this assay, from the lowest: compounds 1, 2 and 3 (each within the scatter of the next).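

In this assay, a second swap of the same size, now on a saturated chain carbon seven bonds along the chain from a double-bonded chain carbon, gives no change at the digits printed from compound 2 to compound 3 (within the scatter). Taken as a whole, the group of 10 heavy atoms in place of the group of 6 heavy atoms gives no change at the digits printed from compound 1 to compound 3 (within the scatter), so across these three compounds the larger swap shows no shift beyond the scatter either. No measurement offered here explains why the numbers stay level.

These compounds leave open whether a longer chain or a shorter chain at this position would hold the same level. They also leave open whether an amine or a carboxylic acid on this saturated stretch would do so.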